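Swapping the pyridinylmethyl arm for benzyl in a phthalazine-piperazine amide

The source may hold more compounds than are shown below. What is called first, only, known or untested is meant among the compounds shown, and "the series" means these compounds.

The series shares a core in which a piperazine links an aromatic bicyclic unit to an acetamide. Compound 1 `O=C(CN1CCN(c2nnc(Cc3ccncc3)c3ccccc23)CC1)Nc1ccc(Br)cc1` carries a (pyridin-4-yl)methyl group on the core and a bromophenyl amide. Among the compounds with values here, in a functional assay on A549 cells (Homo sapiens) for cytotoxicity, read by MTT assay, with a stated time of 72 h (a higher number here means a weaker inhibitor, a lower number a stronger inhibitor), compound 1 gives 2710 nM, and this is the only numerical value in the set. Compound 2 `Cc1ccc(NC(=O)CN2CCN(c3nnc(Cc4ccccc4)c4ccccc34)CC2)c(C)c1` is reported in this assay as "not active" (no number reported), and compound 3 `Cc1ccccc1NC(=O)CN1CCN(c2nnc(Cc3ccccc3)c3ccccc23)CC1` as "not active" (no number reported); both carry benzyl on the core together with methylated phenyl amides, and neither yields a number.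

Compound 4 `O=C(CN1CCN(c2nnc(Cc3ccccc3)c3ccccc23)CC1)Nc1ccc(Br)cc1` keeps the bromophenyl amide of compound 1 and differs from it only in the change (phenyl in place of pyridin-4-yl on a saturated chain carbon bound to an aromatic carbon). The two benzyl analogues, compound 2 and compound 3, return no activity, so a step toward a weaker inhibitor, beyond the scatter, is expected for a 2.6-fold higher number from compound 1 to compound 4 (0.41 log units; beyond the scatter). Compound 4 is accordingly estimated at 7000 nM in this assay, with an expected range from 2500 nM to 25000 nM, and a real chance that only a limit is reported.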

Compound 4, half-maximal inhibitory concentration: 2000 nM
The estimate for compound 4 lay 3.5-fold (0.54 log units) above the measured number, outside the stated range (below it).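

In this assay the step of a 1.4-fold lower number from compound 1 to compound 4 (0.13 log units; within the scatter) lies within the scatter, so at this saturated chain carbon phenyl and pyridin-4-yl cannot be told apart, and the ring nitrogen of compound 1 is not required for a measurable number. Compound 4 carries benzyl and still gives 2000 nM with its bromophenyl amide, so benzyl alone does not account for the "not active" reports of compound 2 and compound 3, which differ from compound 4 in their methylated phenyl amides. Nothing measured here explains why the two arms read alike.

As far as these compounds go, whether a longer chain between the core and the ring, or an amine or carboxylic acid on that ring, would shift the number remains open. So does the part played by the bromine, since a chlorophenyl or unsubstituted phenyl amide on the benzyl core is not among these compounds.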